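The source may hold more compounds than are shown below. What is called first, only, known or untested is meant among the compounds shown, and "the series" means these compounds.

Compound 2 `CCC/C=C/C(=O)Nc1cccc(Oc2nc(Nc3cccc(OC)c3)nc3ccsc23)c1` gives 5560 nM in a functional assay on A549 cells (Homo sapiens) for inhibition, read by MTT assay, with a stated time of 72 h; on this read-out higher numbers stand for weaker inhibition and lower numbers for stronger inhibition. Within the data shown here, of the two numbers measured so far it is the lower one; the other belongs to compound 1 `CC/C=C/C(=O)Nc1cccc(Oc2nc(Nc3cccc(OC)c3)nc3ccsc23)c1`, which in this assay gives 19600 nM. Among the measured compounds shown here, the single measured step, a 3.5-fold lower number from compound 1 to compound 2 (0.55 log units; beyond the scatter), comes from a change on the amide chain. Compound 3 `CCC/C=C/C(=O)Nc1cccc(Oc2nc(Nc3cccc(C#N)c3)nc3ccsc23)c1` differs from compound 2 on a different part of the molecule: cyano in place of methoxy on an aromatic carbon. For the measured compounds named here, no measured step touches that aromatic ring, so nothing seen so far shows how this assay answers the exchange of methoxy for cyano at that place. The expectation for compound 3 therefore rests on compound 2 alone and carries a wide margin of uncertainty. Compound 3 is expected to give about 5000 nM in this assay, within a range from 1500 nM to 20000 nM. From the compounds shown here alone, that expected result amounts to a step of a 1.1-fold lower number from compound 2 to compound 3 (0.05 log units; within the scatter), meaning no change beyond the scatter, with the width of the range standing for what remains unknown.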

Compound 3, half-maximal inhibitory concentration: 16700 nM
Compound 3: middle estimate off by 3.3-fold (0.52 log units), on the low side; measured number inside the range.
By their numbers in this assay, from the lowest: compound 2; then compounds 3 and 1 (each within the scatter of the next).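

In this assay, among these compounds, the exchange of methoxy for cyano on this aromatic carbon, meta to a large group, gives a 3.0-fold higher number from compound 2 to compound 3 (0.48 log units; beyond the scatter) and is the first measured step at this place. It shows that the position is not silent in this assay: the two groups have the same count of heavy atoms, each has one hydrogen-bond acceptor and neither carries a net charge, yet the 3-methoxyphenyl compound shows the stronger inhibition of the pair. No measurement shown here explains why these two groups give different numbers.

Among the compounds shown here, with only two groups read at this place, it remains open how an amine, a carboxylic acid, a fluorine atom or a plain hydrogen would behave there, and so whether methoxy stands out or cyano is the poorer exchange. From the compounds shown here alone, it is also open whether the step would keep its size on the shorter amide chain of compound 1, as the exchange has been read on the chain of compound 2 alone.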